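Chloro for Methyl on a Shared Core

The source may hold more compounds than are shown below. What is called first, only, known or untested is meant among the compounds shown, and "the series" means these compounds.

Of the compounds shown here, two have been tested in a functional assay on MCF7 cells (Homo sapiens) for antiproliferative activity, read by MTT assay, with a stated time of 48 h; on this read-out lower numbers stand for stronger inhibition and higher numbers for weaker inhibition. Compound 1 `N#CC1=C(N)Oc2c(c3nc4ccccc4nc3c3ccccc23)C12C(=O)N(Cc1cnnn1-c1ccc(F)c(Cl)c1)c1ccccc12` gives > 50000 nM, which is a limit of the assay rather than a number. Compound 2 `Cc1ccccc1-n1nncc1CN1C(=O)C2(C(C#N)=C(N)Oc3c(N)cc4nc5ccccc5nc4c32)c2ccccc21` likewise gives > 50000 nM in this assay, again a limit. Compound 2 thus stands at the boundary of what the assay reports, and the other value shown is a limit as well (the limit of > 50000 nM in this assay, at which 2 of the 2 values shown sit). For the measured compounds named here, no step between two measured compounds that differ in one place is available.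

Compound 3 `N#CC1=C(N)Oc2c(N)cc3nc4ccccc4nc3c2C12C(=O)N(Cc1cnnn1-c1ccccc1Cl)c1ccccc12` has not yet been measured. It differs from compound 2 as follows: chloro in place of methyl on an aromatic carbon, ortho to a large group. Going by the values given here, there is no measured step from which a direction could be read. The expectation is that this small change leaves compound 3 near the limit as well, with a step expected to be none beyond the scatter a number no higher from compound 2 to compound 3 (the limit leaves the size open). For compound 3 the estimate in this assay is 50000 nM, expected to lie between 15000 nM and 150000 nM, and most likely reported once more only as a limit.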

Compound 3, half-maximal inhibitory concentration: 34400 nM
Beside the measured number, compound 3's estimate is 1.5-fold (0.16 log units) above it, within the range that was stated.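

Compound 3 is the first compound shown for which this assay returns a number rather than a limit, so this position on the aromatic ring now has a value against which other groups can be set. The change from 2-methylphenyl to 2-chlorophenyl, which swaps one heavy atom for one heavy atom on the shared core, comes with an at least 1.4-fold lower number from compound 2 to compound 3 (0.16 log units; that floor lies within the scatter) and so does not establish a difference larger than the usual scatter of the assay. Only a floor can be given for this step, and not its full size, because the value of compound 2 is a limit: the limit of > 50000 nM in this assay, at which 2 of the 3 values shown sit.

What the compounds shown leave open is whether a different group at this same place, such as a bromo, methoxy or amine group, would bring the number clearly beyond the scatter of what compound 3 gives, or whether the read-out would stay in this high range whatever stands there. Compound 1 differs from compound 3 in more than one place, so it offers no comparison that could settle this.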